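Fluoro in place of hydrogen across two cores

The compounds below may be only part of what the source reports. "The series", "measured", "known", "first", "only" and "open" are said of these compounds alone.

Compound 1 `N=C(N)Nc1cccc(C(=O)NNC(=O)CC(CC(=O)O)c2ccccc2)c1` and compound 2 `N=C(N)Nc1cccc(C(=O)NNC(=O)CC(CC(=O)O)c2ccc(F)cc2)c1` share one core. Compound 3 `O=C(O)CC(CC(=O)NNC(=O)CCCCNc1ccccn1)c1ccccc1` is built on a second core; the difference between the two cores is not broken down here. Compound 4 `O=C(O)CC(CC(=O)NNC(=O)CCCCNc1ccccn1)c1ccc(F)cc1` is the analogue of compound 3 and has not yet been measured.

In a physicochemical assay for lipophilicity (a higher number here means a more lipophilic compound, a lower number a more polar compound), compound 1 gives 1.13. In this assay compound 2 gives 1.28. The change between them is fluoro in place of hydrogen on an aromatic carbon and the step it makes is a number 0.15 log units higher from compound 1 to compound 2 (within the scatter). In this assay compound 3 gives 2.07, which stands apart from both compound 1 and compound 2 beyond the scatter.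

The change from compound 3 to compound 4 is fluoro in place of hydrogen on an aromatic carbon. Its place reads the same, word for word, as for the first pair, so this is the same change carried onto a different core. Among the compounds shown it occurs twice, once measured and once not.

Because the same change gave a number 0.15 log units higher from compound 1 to compound 2 (within the scatter), the step from compound 3 to compound 4 is expected to be a number 0.15 log units higher from compound 3 to compound 4 (within the scatter). That expectation rests on a single measured pair on another core, so the range is kept wide. For compound 4 in this assay the estimate is 2.22, with the likely span running from 1.95 to 2.5.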

Compound 4, partition coefficient: 2.23
Estimate against measurement, compound 4: 0.01 log units below, and the stated range covers the measured number.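

In this assay, phenyl to 4-fluorophenyl on the second core gives a number 0.16 log units higher from compound 3 to compound 4 (within the scatter), and the same change on the first core gave a number 0.15 log units higher from compound 1 to compound 2 (within the scatter). Going by these compounds alone, the two pairs therefore agree in that, on both cores, the step stays inside the scatter, so within these four compounds the change carries from one core to the other without a step that stands clear of repeated measurement; this does not show that fluoro in place of hydrogen moves the number at all, nor that the agreement would hold on any core beyond these two, since it rests on only two pairs and neither step can be told from noise. No measurement available here bears on why the two steps read alike.

The compounds shown leave open whether a larger group in the same place, such as chloro, methyl or trifluoromethyl, would give a step beyond the scatter, and whether such a step would then carry between the two cores as closely. They also leave open how the fluoro change reads in any read-out other than this assay, and what part of the gap between the two cores comes from which part of their structures.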